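A Methoxy for Bromo Swap on a Weak Series

The source may report more compounds than this note shows. Statements on the series, on what has been measured and on what is new or still open speak of the compounds shown alone.

Three compounds share one core and differ only in the group carried on a nitrogen of that core, and all were tested in a functional assay on MDA-MB-468 cells (Homo sapiens) for antiproliferative activity, read by MTT assay, with a stated time of 24 h; on this read-out lower numbers stand for stronger inhibition and higher numbers for weaker inhibition. Compound 1 `CNC(=O)c1ccccc1Oc1nc(Nc2ccccc2F)ncc1Br` carries a 2-fluorophenyl group; in this assay compound 1 reaches only > 50000 nM, which is a limit of the measurement and not a number. Compound 2 `CNC(=O)c1ccccc1Oc1nc(Nc2cccc(Br)c2)ncc1Br` bears a 3-bromophenyl group, and in this assay compound 2 gives 31900 nM. Compound 3 `CNC(=O)c1ccccc1Oc1nc(Nc2ccc(C)cc2C)ncc1Br` has a 2,4-dimethylphenyl group; in this assay compound 3 gives 40700 nM. Of the two real numbers, compound 2 stands at the lower one, but that standing is not secured, since a 1.3-fold higher number from compound 2 to compound 3 (0.11 log units; within the scatter). The steps from the limit are floors only: an at least 1.5-fold lower number from compound 1 to compound 2 (0.19 log units; that floor lies within the scatter) and an at least 1.2-fold lower number from compound 1 to compound 3 (0.08 log units; that floor lies within the scatter). Taken together, varying the group on this nitrogen has moved this assay little, and none of the three shifts is known to exceed the scatter.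

Compound 4 `CNC(=O)c1ccccc1Oc1nc(Nc2cccc(OC)c2)ncc1Br` is not yet measured. Compared with compound 2 the change is: methoxy in place of bromo on an aromatic carbon. Among the measured compounds shown here, the steps that bear on this change are the three just described, all small or only floors. No step beyond the scatter is therefore expected, and the estimated step from compound 2 to compound 4 is a 1.1-fold higher number from compound 2 to compound 4 (0.04 log units; within the scatter). Compound 4 is expected to give about 35000 nM in this assay, within a range from 15000 nM to 80000 nM.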

Compound 4, half-maximal inhibitory concentration: 17800 nM
Compound 4: the middle estimate sits 2.0-fold (0.29 log units) above what was measured; the range from low to high includes it.
By their numbers in this assay, from the lowest: compounds 4, 2 and 3 (each within the scatter of the next, the first and the last beyond it). At a limit, above all of these: compound 1.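

In this assay, the swap of bromo for methoxy gives a 1.8-fold lower number from compound 2 to compound 4 (0.25 log units; within the scatter), so the two groups cannot be told apart at this place on the ring, even though methoxy adds a hydrogen-bond acceptor and one more heavy atom. The series does now hold its first steps known to pass the usual scatter: changing 2,4-dimethylphenyl to 3-methoxyphenyl on the nitrogen gives a 2.3-fold lower number from compound 3 to compound 4 (0.36 log units; beyond the scatter), a modest step, which shows that the choice of group here can move this read-out at least somewhat. The other such step, an at least 2.8-fold lower number from compound 1 to compound 4 (0.44 log units; beyond the scatter), is only a floor, and its true size is unknown, since compound 1 sits at a limit and not at a real number: the limit of > 50000 nM in this assay, at which 1 of the 4 values shown sits.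

The compounds shown leave open what an amine, a hydroxyl or a longer ether such as ethoxy would do at this same place on the ring. They also leave open what would happen in this assay if the bromo on the shared core gave way to another group, such as a nitrile.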